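The source may hold more compounds than are shown below. What is called first, only, known or untested is meant among the compounds shown, and "the series" means these compounds.

Working notes on the series. In a functional assay on HepG2 cells (Homo sapiens) for cytotoxicity, read by MTT assay (a higher number here means a weaker inhibitor, a lower number a stronger inhibitor), compound 1 (`COc1ccc(/C=C/C(=O)c2ccc(OC)c3c2OC(C)(C)C=C3)cc1OCC=C(C)C`) gives > 10000 nM, which is a limit and not a number. Compound 2 (`C#CCOc1cc(/C=C/C(=O)c2ccc(OC)c3c2OC(C)(C)C=C3)ccc1OC`) gives > 10000 nM, also a limit. Compound 3 (`COc1ccc(/C=C/C(=O)c2ccc(OC)c3c2OC(C)(C)C=C3)cc1OCCO`) gives > 10000 nM, again a limit. Compound 2 therefore has no number of its own, and the evidence so far is the limit of > 10000 nM in this assay, at which 3 of the 3 values shown sit.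

Compound 4 (`COc1ccc(/C=C/C(=O)c2ccc(OC)c3c2OC(C)(C)C=C3)cc1OCCCN(C)C`) differs from compound 2 in one group: 2-(dimethylamino)ethyl in place of ethynyl on a saturated chain carbon bound to an oxygen on an aromatic ring. Three measured steps fall at this same place: a step that the two limits leave unreadable from compound 1 to compound 2, a step that the two limits leave unreadable from compound 1 to compound 3 and a step that the two limits leave unreadable from compound 2 to compound 3. None of them has a readable size, so the series offers no measured size or direction for a change here. With nothing to move the expectation away from the limit, the starting point stays at compound 2 with its limit of > 10000 nM. The expected change is a number no higher from compound 2 to compound 4 (the limit leaves the size open), with no step beyond the scatter anticipated. For compound 4 the estimated value is 10000 nM, with an expected range of 4000 nM to 25000 nM.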

Compound 4, half-maximal inhibitory concentration: 5550 nM
Compound 4: the middle estimate sits 1.8-fold (0.26 log units) above what was measured; the measured number falls inside the stated range.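

In this assay compound 4 gives 5550 nM, the only value at this position that is a number and not a limit, so the 3-(dimethylamino)propyl chain is the one group shown that yields a readable value. Its steps are an at least 1.8-fold lower number from compound 2 to compound 4 (0.25 log units; that floor lies within the scatter), an at least 1.8-fold lower number from compound 3 to compound 4 (0.25 log units; that floor lies within the scatter) and an at least 1.8-fold lower number from compound 1 to compound 4 (0.25 log units; that floor lies within the scatter); each gives only a floor, so the true size of the change remains unfixed. The rest of the position still stands at a single limit: the limit of > 10000 nM in this assay, at which 3 of the 4 values shown sit.

From the compounds shown here alone, how far compound 1, compound 2 and compound 3 truly lie from compound 4 remains open. Also open, going by these compounds, is whether the dimethylamino end or the chain length matters, a question that a shorter chain ending in dimethylamino, or a morpholine or carboxylic acid at the chain end, would address.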